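From phenyl to 4-(trifluoromethyl)phenyl: a small step expected

The source may hold more compounds than are shown below. What is called first, only, known or untested is meant among the compounds shown, and "the series" means these compounds.

Measured so far in an ADME assay on J774 cells (Mus musculus) for antiproliferative activity, with a stated time of 72 h (on this read-out higher numbers stand for an effect only at larger amounts of compound and lower numbers for an effect already at smaller amounts), are these results:
- compound 1 (`CCCCc1cc2c(=O)c(CC)c(C)[nH]c2cc1OCCOc1ccccc1`) 1000 nM
- compound 2 (`CCc1c(C)[nH]c2cc(OCCCO)c(Cl)cc2c1=O`) "not determined" (no result reported)
- compound 3 (`CCCCc1cc2c(=O)c(-c3ccccc3)c(C)[nH]c2cc1OCCOc1ccccc1`) 23000 nM

Compound 3 has the higher of the two numbers, so it needs the larger amount to act. Compound 4 (`CCCCc1cc2c(=O)c(-c3ccc(C(F)(F)F)cc3)c(C)[nH]c2cc1OCCOc1ccccc1`) has trifluoromethyl in place of hydrogen on an aromatic carbon of the phenyl ring of compound 3 (trifluoromethyl in place of hydrogen on an aromatic carbon). For the measured compounds named here, only one measured step bears on this: a 23-fold higher number from compound 1 to compound 3 (1.36 log units; beyond the scatter) when phenyl replaced ethyl. That large step exchanged a whole group, whereas here the phenyl stays, so it gives no clear direction. In this assay the step expected is a 1.2-fold lower number from compound 3 to compound 4 (0.06 log units; within the scatter) and so lies within the scatter. Compound 4 is estimated at 20000 nM with a range from 7000 nM to 60000 nM around it.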

Compound 4, half-maximal effective concentration: 20000 nM
Compound 4: the middle estimate sits on the measured number at the digits printed, within the range that was stated.
By their numbers in this assay, from the lowest: compound 1; then compounds 4 and 3 (each within the scatter of the next).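

In this assay the step of a 1.2-fold lower number from compound 3 to compound 4 (0.06 log units; within the scatter) stays within the scatter, so trifluoromethyl on the phenyl ring leaves the read-out where plain phenyl put it. The substituted ring still stands apart from ethyl, with a 20-fold higher number from compound 1 to compound 4 (1.30 log units; beyond the scatter) lying beyond the scatter, so the large earlier step holds for this phenyl as well. No measurement shown explains either result.

From the compounds shown here alone, whether an amine or a carboxylic acid on the phenyl ring would shift the number remains open. So does whether a longer chain in place of ethyl would give a number lower than that of compound 1.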